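The source may report more compounds than this note shows. Statements on the series, on what has been measured and on what is new or still open speak of the compounds shown alone.

Three compounds share one core and differ only in the group carried on an amide-type nitrogen. Compound 1 `Cc1ccc(NC(=O)CN2C(=O)/C(=N\NC(=O)Cn3ccc(=O)c(O)c3C)c3ccccc32)cc1` gives in a functional assay on MCF7 cells (Homo sapiens) for cytotoxicity, read by MTT assay, with a stated time of 48 h (a lower number here means that less compound is needed, a higher number that more compound is needed for the effect), a value of 52200 nM. Compound 2 `Cc1c(O)c(=O)ccn1CC(=O)N/N=C1\C(=O)N(CC(=O)Nc2ccccc2)c2ccccc21` gives in this assay a value of 48400 nM, and compound 3 `CC(=O)Nc1ccc(NC(=O)CN2C(=O)/C(=N\NC(=O)Cn3ccc(=O)c(O)c3C)c3ccccc32)cc1` gives in this assay a value of 51900 nM. Among these three numbers compound 3 stands second highest, with compound 1 nearest and compound 2 furthest, and all three lie within the usual scatter of one another, so no ranking among them can be drawn.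

Compound 4 `Cc1cccc(NC(=O)CN2C(=O)/C(=N\NC(=O)Cn3ccc(=O)c(O)c3C)c3ccccc32)c1C` is the next compound. Its difference from compound 3 is 2,3-dimethylphenyl in place of 4-acetamidophenyl on an amide-type nitrogen. For the measured compounds named here, the steps measured so far each changed only one group on an aromatic carbon of this same phenyl ring: a 1.1-fold lower number from compound 1 to compound 2 (0.03 log units; within the scatter), a 1.0-fold lower number from compound 1 to compound 3 (0.00 log units; within the scatter) and a 1.1-fold higher number from compound 2 to compound 3 (0.03 log units; within the scatter). Each of them lay within the scatter. The change to compound 4 is broader than any of these, since it exchanges the whole substituted phenyl, yet exchanging hydrogen, methyl and acetamido on this ring left the numbers untouched. With nothing pointing the other way, the step from compound 3 to compound 4 is expected to be a 1.0-fold higher number from compound 3 to compound 4 (0.00 log units; within the scatter), a change not beyond the scatter. Compound 4 is therefore estimated at 52000 nM in this assay, with a range from 26000 nM to 105000 nM.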

Compound 4, half-maximal effective concentration: 51900 nM
Compound 4: the middle estimate sits 1.0-fold (0.00 log units) above what was measured; the measured number falls inside the stated range.
By their numbers in this assay, from the lowest: compounds 2, 3, 4 and 1 (each within the scatter of the next).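

In this assay, the exchange on the amide-type nitrogen now replaces the whole 4-acetamidophenyl, with its 1 hydrogen-bond donor and 1 hydrogen-bond acceptor, by 2,3-dimethylphenyl, which has neither, and the result is no change at the digits printed from compound 3 to compound 4 (within the scatter). Set against the phenyl and 4-methylphenyl groups, the same 2,3-dimethylphenyl group gives a 1.1-fold higher number from compound 2 to compound 4 (0.03 log units; within the scatter) and a 1.0-fold lower number from compound 1 to compound 4 (0.00 log units; within the scatter), so a ring carrying two methyl groups also stays within the scatter of the other three compounds, something the earlier exchanges of a single group could not show. No measurement at hand gives a reason why these four numbers lie so close together.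

From the compounds shown here alone, all four compounds carry a substituted or plain phenyl ring on this nitrogen, so it remains open whether a carboxylic acid or an amine on that ring, or a longer alkyl chain in place of the ring, would give a number outside this narrow band. The rest of the shared core is identical throughout, so these compounds cannot tell how its other parts bear on the numbers in this assay.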